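Working notes: replacing 4-hydroxycyclohexyl in compound 1

This account rests on a few compounds, and the source may have more. Where it says the series, first, only, none or still open, it means among the compounds named here.

Compound 1 `O=C(NCCNS(=O)(=O)c1ccc(-c2ccccc2O[C@H]2CC[C@H](O)CC2)s1)Nc1cc(C(F)(F)F)cc(C(F)(F)F)c1`: 7100 nM
Compound 2 `COc1ccc(Oc2ccccc2-c2ccsc2S(=O)(=O)N2CCN(C(=O)Nc3ccc(F)cc3)CC2)cc1OC`: > 20000 nM

Among the compounds with values here, in a functional assay on HL-60 cells (Homo sapiens) for inhibition, read by CCK-8 assay, with a stated time of 48 h (on this read-out higher numbers stand for weaker inhibition and lower numbers for stronger inhibition), compound 1 gives 7100 nM, the only actual number so far. The entry for compound 2 is a limit of the assay, not a number.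

Compound 3 `O=C(NCCNS(=O)(=O)c1ccc(-c2ccccc2Oc2ccc(O)c(O)c2)s1)Nc1cc(C(F)(F)F)cc(C(F)(F)F)c1` has 3,4-dihydroxyphenyl in place of 4-hydroxycyclohexyl on an oxygen on an aromatic ring. Within the data shown here, no measured pair shows this change, so the expectation is tentative. A modest strengthening in this assay is expected, with the estimated change being a 1.8-fold lower number from compound 1 to compound 3 (0.25 log units; within the scatter). For compound 3 the estimated value is 4000 nM, with an expected range of 1000 nM to 16000 nM.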

Compound 3, half-maximal inhibitory concentration: 10500 nM
Beside the measured number, compound 3's estimate is 2.6-fold (0.42 log units) below it; low and high end bracket the measured number.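

In this assay, 3,4-dihydroxyphenyl in place of 4-hydroxycyclohexyl on an oxygen on an aromatic ring gives a 1.5-fold higher number from compound 1 to compound 3 (0.17 log units; within the scatter). This position therefore accepts a six-membered aromatic ring in place of a non-aromatic one with no readable change, and the two defined stereocentres of 4-hydroxycyclohexyl are not required to keep a measured value. Nothing measured here bears on a reason for this step.

As far as these compounds go, whether plain phenyl or 4-aminocyclohexyl on the same oxygen would move the number beyond the scatter remains open.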